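This account rests on a few compounds, and the source may have more. Where it says the series, first, only, none or still open, it means among the compounds named here.

Measured so far:
compound 1, `C[C@@H](O)CCn1nc2c(Br)c(Br)c(Br)c(Br)c2n1`: 24%
compound 2, `OC(CCn1nc2c(Br)c(Br)c(Br)c(Br)c2n1)c1cccc(Cl)c1`: 0%

In a functional assay on CCRF-CEM cells (Homo sapiens) for antiproliferative activity, read by MTT assay, with a stated time of 48 h, tested at 100 uM (a lower number here means a stronger effect, a higher number a weaker effect of the compound at the concentration tested), compound 1 gives 24%, while compound 2 gives 0%. Compound 2 therefore has the lowest of the two numbers, and its nearest neighbour, compound 1, lies a good deal higher, a gap that is beyond the usual scatter. Since a lower number means a stronger effect here, compound 2 is the stronger of the pair at the concentration tested.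

Compound 3, `COc1cccc(C(O)CCn2nc3c(Br)c(Br)c(Br)c(Br)c3n2)c1`, has not yet been measured. It differs from compound 2 in one place: methoxy in place of chloro on an aromatic carbon. Among the measured compounds shown here, no measured pair shows this change, so its effect is unknown. With compound 2 already at the bottom of the scale, a step from compound 2 to compound 3 of about a number 8 percentage points higher from compound 2 to compound 3 (within the scatter) is expected, at most a small rise and possibly none beyond the scatter. Compound 3 is expected to give about 8%, between 0% and 30%.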

Compound 3, a percentage reported as activity, at one concentration (the size of the read-out at that concentration, not a potency): 2%
The estimate for compound 3 lay 6 percentage points above the measured number; the measured number falls inside the stated range.
By their numbers in this assay, from the lowest: compounds 2 and 3 (each within the scatter of the next); then compound 1.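

In this assay, the change from 3-chlorophenyl to 3-methoxyphenyl gives a number 2 percentage points higher from compound 2 to compound 3 (within the scatter), so at this position on the aromatic ring the two groups cannot be told apart at the concentration tested. With compound 2 at 0% and compound 3 at 2%, both numbers lie at or close to the bottom of the scale, and a read-out at one concentration gives no measure of potency, so a real difference between them could remain hidden. No measured evidence bears on why the two groups read alike.

On these data alone, it remains open whether an amine or a carboxylic acid at the same place would also leave the number near the bottom of the scale. A plain phenyl ring without any such group also remains to be compared with compound 2 and compound 3.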